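Swapping the triazole for an oxazole on the shared core

The source may hold more compounds than are shown below. What is called first, only, known or untested is meant among the compounds shown, and "the series" means these compounds.

Compound 1 `CC(C)C(c1nnc[nH]1)c1ccc(-c2ccc3cccc(F)c3c2)[nH]c1=O` is the starting point of this series. In an ADME assay on microsomes from liver (Homo sapiens) for metabolic stability (on this read-out higher numbers stand for a longer-lived compound and lower numbers for a shorter-lived compound), compound 1 gives 0.905 h, the highest of the three numbers. Compound 2 `CC(C)NC(=O)CC(c1ccc(-c2ccc3cccc(F)c3c2)[nH]c1=O)C(C)C` gives 0.32 h, and compound 3 `CC(C)C(c1ccc(-c2ccc3cccc(F)c3c2)[nH]c1=O)N1CCN/C1=N\C#N` gives 0.632 h. The two steps that replace the same group on the same carbon are a 2.8-fold lower number from compound 1 to compound 2 (0.45 log units; beyond the scatter) and a 1.4-fold lower number from compound 1 to compound 3 (0.16 log units; within the scatter), so both replacements of this ring lowered the number, one of them only within the scatter. Compound 4 `CC(C)C(c1ncco1)c1ccc(-c2ccc3cccc(F)c3c2)[nH]c1=O` differs from compound 1 by 1,3-oxazol-2-yl in place of 4H-1,2,4-triazol-3-yl on a saturated chain carbon bound to an aromatic carbon and a saturated chain carbon. Within the data shown here, since the one aromatic-for-aromatic change here keeps the ring, a step no larger than a 1.5-fold lower number from compound 1 to compound 4 (0.18 log units; within the scatter) is expected for compound 4, in the downward direction. The estimate for compound 4 in this assay is 0.6 h, within a range of 0.3 h to 1.2 h.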

Compound 4, half-life: 0.178 h
Beside the measured number, compound 4's estimate is 3.4-fold (0.53 log units) above it; measured number outside the range, below it.
By their numbers in this assay, from the lowest: compounds 4, 2, 3 and 1 (each within the scatter of the next, the first and the last beyond it).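

In this assay, keeping an aromatic five-membered ring on this saturated chain carbon does not keep the number: 1,3-oxazol-2-yl gives a 5.1-fold lower number from compound 1 to compound 4 (0.71 log units; beyond the scatter) and so costs more than the ring's aromatic character alone would suggest. The same group also gives a 3.6-fold lower number from compound 3 to compound 4 (0.55 log units; beyond the scatter) and, against the open chain, a 1.8-fold lower number from compound 2 to compound 4 (0.25 log units; within the scatter), which leaves compound 2 and compound 4 within the scatter of each other. Nothing measured here accounts for this result. The compounds shown leave open how an imidazole or a carboxylic acid on this carbon would fare, and whether any other ring matches the 4H-1,2,4-triazol-3-yl group.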